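The source may report more compounds than this note shows. Statements on the series, on what has been measured and on what is new or still open speak of the compounds shown alone.

Measured in a functional assay on SK-OV-3 cells (Homo sapiens) for antiproliferative activity, read by MTT assay, with a stated time of 72 h; on this read-out higher numbers stand for weaker inhibition and lower numbers for stronger inhibition:
- compound 1 `O=C(CCc1cccc2c1B(O)OC2)Nc1cccc(-c2cccc(Cl)c2)c1`: 300 nM
- compound 2 `COc1ccc(-c2cccc(NC(=O)CCc3cccc4c3B(O)OC4)c2)cc1`: 48 nM
- compound 3 `CSc1cccc(-c2cccc(NC(=O)CCc3cccc4c3B(O)OC4)c2)c1`: 150 nM

Compound 3 stands in the upper part of these three numbers, clearly apart from the lowest: a 3.1-fold higher number from compound 2 to compound 3 (0.49 log units; beyond the scatter).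

Compound 4 `O=C(CCc1cccc2c1B(O)OC2)Nc1cccc(-c2cccc(C(F)(F)F)c2)c1` carries trifluoromethyl in place of methylsulfanyl on an aromatic carbon, meta to a large group. Going by the values given here, the closest precedent is the exchange of chloro for methylsulfanyl at that place, a 2.0-fold lower number from compound 1 to compound 3 (0.30 log units; within the scatter). The change to 4-methoxyphenyl, a 6.3-fold lower number from compound 1 to compound 2 (0.80 log units; beyond the scatter), is a different exchange of the whole aryl group and bears on this step less directly. Among the compounds with values here, no measured compound carries trifluoromethyl, so the basis is thin. In this assay, a step beyond the scatter is not expected, with a slight lean towards a higher number. The expected step is a 1.5-fold higher number from compound 3 to compound 4 (0.17 log units; within the scatter). For compound 4 the estimated value is 220 nM, with an expected range of 90 nM to 550 nM.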

Compound 4, half-maximal inhibitory concentration: 390 nM
Compound 4: the middle estimate sits 1.8-fold (0.25 log units) below what was measured; the measured number falls inside the stated range.
By their numbers in this assay, from the lowest: compound 2; then compounds 3, 1 and 4 (each within the scatter of the next, the first and the last beyond it).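

In this assay, trifluoromethyl in place of methylsulfanyl on this aromatic carbon moves the number beyond the scatter (a 2.6-fold higher number from compound 3 to compound 4 (0.41 log units; beyond the scatter)), whereas trifluoromethyl in place of chloro stays within it (a 1.3-fold higher number from compound 1 to compound 4 (0.11 log units; within the scatter)), so chloro sits within the scatter of both other groups and these three groups give no clean ranking. The 4-methoxyphenyl group of compound 2 now stands beyond the scatter of all three other aryl groups, with the largest step in the set (an 8.1-fold higher number from compound 2 to compound 4 (0.91 log units; beyond the scatter)). Nothing measured here accounts for these steps.

The compounds leave open whether the gain in compound 2 belongs to the methoxy group itself or to where it sits on the ring, since only the 4-methoxyphenyl group carries it. As far as these compounds go, how an amine or a carboxylic acid at this place would read in this assay also stays open.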